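Thiazolyl trimethoxyphenyl ketones: ester in place of ethyl

The source may report more compounds than this note shows. Statements on the series, on what has been measured and on what is new or still open speak of the compounds shown alone.

Measured compounds in a functional assay on PC-3 cells (Homo sapiens) for cytotoxicity, read by sulforhodamine B assay, with a stated time of 48 h; on this read-out higher numbers stand for weaker inhibition and lower numbers for stronger inhibition:
Compound 1, `CCc1ccc(-c2nc(C(=O)c3cc(OC)c(OC)c(OC)c3)cs2)cc1`, gives 27 nM.
Compound 2, `COc1cc(NC(=O)[C@@H]2CSC(c3cc(OC)c(OC)c(OC)c3)N2)cc(OC)c1OC`, gives > 20000 nM, which is a limit of the assay and not a number.
Compound 3, `COc1cc(NC(=O)[C@H]2CSC(c3ccccc3)=N2)cc(OC)c1OC`, gives 13200 nM.

Of the two numbers shown, compound 1 gives the lowest. Compound 3 gives a higher number, and that gap lies beyond the scatter. Compound 2 sits at the limit of > 20000 nM in this assay, at which 1 of the 3 values shown sits, so it cannot be placed on the same scale. Going by the values given here, compounds 2 and 3 differ from compound 1 in more than one place, so no single measured step describes any one change in this set.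

Compound 4, `COC(=O)c1ccc(-c2nc(C(=O)c3cc(OC)c(OC)c(OC)c3)cs2)cc1`, is not yet measured. It differs from compound 1 by methoxycarbonyl in place of ethyl on an aromatic carbon. The shared core and the trimethoxyphenyl ketone are kept; only the substituent on the distal ring changes. Among the compounds with values here, no measured pair isolates this change, so the expectation rests on the size of the group exchanged and on compound 1 holding the lowest number. The step from compound 1 to compound 4 is expected to be small, at most a modest move toward a higher number, a 2.2-fold higher number from compound 1 to compound 4 (0.35 log units; beyond the scatter), and possibly within the scatter. Compound 4 is estimated at 60 nM, with a range from 15 nM to 300 nM.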

Compound 4, half-maximal inhibitory concentration: > 20000 nM
Compound 4: no number, only a limit (the forecaster's own chance of this, stated with the estimate: 5%); middle value at least 330-fold (2.52 log units) away from the limit.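

Methoxycarbonyl in place of ethyl on an aromatic carbon, para to a large group, gives an at least 740-fold higher number from compound 1 to compound 4 (2.86 log units; beyond the scatter); this is the first single-place step in the series, and it shows that the read-out in this assay depends strongly on this substituent. With the shared core and the trimethoxyphenyl ketone kept, the loss in compound 4 can be traced to this one exchange alone, which the multi-place differences of compounds 2 and 3 could not show. Compound 4 gives > 20000 nM, which is a limit of the assay and not a number, so the step has a lower bound but no exact size: the limit of > 20000 nM in this assay, at which 2 of the 4 values shown sit.

Only ethyl and methoxycarbonyl are shown at this place, so it remains open whether a longer chain such as propyl, a small group such as methyl, or a methoxy group would stay close to compound 1, and whether a carboxylic acid, a primary amide or an amine would share the limit of compound 4. A single step also cannot tell whether the loss belongs to the carbonyl, to the ester as a whole or to the larger group entering.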